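Compound 4: a new group on the carbonyl carbon

The compounds below may be only part of what the source reports. "The series", "measured", "known", "first", "only" and "open" are said of these compounds alone.

Compound 1 `CCN1CCN(c2cc(C)c3cc(NC(=O)c4cc(Cl)cc(Cl)c4)ccc3n2)CC1`: 2660 nM
Compound 2 `CCN1CCN(c2cc(C)c3cc(NC(=O)c4cc5ccccc5[nH]4)ccc3n2)CC1`: 2550 nM
Compound 3 `CCN1CCN(c2cc(C)c3cc(NC(=O)c4ccc5ccccc5n4)ccc3n2)CC1`: 3760 nM

All three values come from a functional assay on SK-BR-3 cells (Homo sapiens) for antiproliferative activity, read by MTT assay, with a stated time of 72 h; on this read-out higher numbers stand for weaker inhibition and lower numbers for stronger inhibition. These compounds share one core and differ only in the group on the carbonyl carbon of the amide. Compound 3 is not set apart from the other two. The steps that reach it are a 1.4-fold higher number from compound 1 to compound 3 (0.15 log units; within the scatter) and a 1.5-fold higher number from compound 2 to compound 3 (0.17 log units; within the scatter).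

The next compound is compound 4 `CCN1CCN(c2cc(C)c3cc(NC(=O)c4cccc(Br)c4)ccc3n2)CC1`, which carries 3-bromophenyl in place of quinolin-2-yl on a carbonyl carbon.

The same position changed in a 1.0-fold lower number from compound 1 to compound 2 (0.02 log units; within the scatter) as well, so all three measured steps bear on this one, and none goes beyond the scatter. The group in compound 4 looks most like the 3,5-dichlorophenyl of compound 1, which gives 2660 nM. No step beyond the scatter is therefore expected in this assay.

The expected step is a 1.3-fold lower number from compound 3 to compound 4 (0.11 log units; within the scatter).

For compound 4, the estimated value is 2900 nM, with an expected range of 1500 nM to 5500 nM.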

Compound 4, half-maximal inhibitory concentration: 13300 nM
Compound 4: the middle estimate sits 4.6-fold (0.66 log units) below what was measured; the whole stated range lies below it.
By their numbers in this assay, from the lowest: compounds 2, 1 and 3 (each within the scatter of the next); then compound 4.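

Within the data shown here, the group on the carbonyl carbon had so far made no difference beyond the scatter, but this position can matter in this assay: compound 4 stands apart from all three earlier compounds (a 3.5-fold higher number from compound 3 to compound 4 (0.55 log units; beyond the scatter); a 5.2-fold higher number from compound 2 to compound 4 (0.72 log units; beyond the scatter); a 5.0-fold higher number from compound 1 to compound 4 (0.70 log units; beyond the scatter)). A single benzene ring on the carbonyl carbon does not account for this, as compound 1 also carries one and stays with the two bicyclic amides, so the difference from compound 1 lies in how that ring is substituted. Nothing measured here explains the step.

The compounds shown leave open whether the bromine itself or the lack of a second halogen sets compound 4 apart. Plain phenyl, 3-chlorophenyl and 3,5-dibromophenyl on the same carbonyl carbon would bear directly on that question.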